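The compounds below may be only part of what the source reports. "The series", "measured", "known", "first", "only" and "open" are said of these compounds alone.

Compound 1 `Cc1ccc(CN(C)CCCn2c(=O)oc3ccccc32)cc1` gives 871 nM in an assay on membranes from liver for displacement of a labelled ligand from Sigma non-opioid intracellular receptor 1 (Rattus norvegicus), read by scintillation counting; a lower number here means a stronger inhibitor, a higher number a weaker inhibitor.
Compound 2 `COc1ccccc1CN(C)CCCCn1c(=O)oc2ccccc21` gives 594 nM in this assay.

Of these two numbers, compound 1 stands at the higher one, although its gap to compound 2 lies within the usual scatter of repeated measurements. Compound 3 `CN(CCCn1c(=O)oc2ccccc21)Cc1ccccc1` has not yet been measured. It differs from compound 1 in a single place: hydrogen in place of methyl on an aromatic carbon. Within the data shown here, no pair of measured compounds shows this change on its own, so the expected step in this assay is none beyond the scatter, in either direction. Compound 3 is therefore estimated at 900 nM, with a range from 300 nM to 2700 nM, which means an expected step of a 1.0-fold higher number from compound 1 to compound 3 (0.01 log units; within the scatter).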

Compound 3, inhibition constant: 223 nM
For compound 3 the middle estimate is 4.0-fold (0.61 log units) above the measured one, and the stated range ends above it.
By their numbers in this assay, from the lowest: compound 3; then compounds 2 and 1 (each within the scatter of the next).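

The change from 4-methylphenyl to phenyl gives a clear step in this assay: a 3.9-fold lower number from compound 1 to compound 3 (0.59 log units; beyond the scatter). At this place on the aromatic ring, para to a large group, a single methyl therefore matters, and compound 3, with hydrogen there, is the stronger inhibitor of the pair. No measurement shown here explains this step.

On these data alone, whether a fluorine, a methoxy group or a hydroxyl group at this place would lower or raise the number stays open. So does whether the same step would appear with a longer chain.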